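A Thiophene-Pyridine Swap on the Shared Core

The compounds below may be only part of what the source reports. "The series", "measured", "known", "first", "only" and "open" are said of these compounds alone.

In a functional assay on HeLa cells (Homo sapiens) for inhibition, with a stated time of 72 h (a higher number here means a weaker inhibitor, a lower number a stronger inhibitor), compound 1 (`COc1ccccc1-c1ccc(CNc2nc(NC3CCC(N)CC3)nc3c2ncn3C2CCCC2)cc1`) gives 333 nM and compound 2 (`NC1CCC(Nc2nc(NCc3ccc(-n4cccn4)cc3)c3ncn(C4CCCC4)c3n2)CC1`) gives 170 nM, and these two values lie within the scatter of each other. Compound 3 (`NC1CCC(Nc2nc(NCc3ccc(-c4cccs4)nc3)c3ncn(C4CCCC4)c3n2)CC1`) differs from compound 2 as follows: 6-(thiophen-2-yl)pyridin-3-yl in place of 4-(1H-pyrazol-1-yl)phenyl on a saturated chain carbon bound to a nitrogen on an aromatic ring. It carries 6-(thiophen-2-yl)pyridin-3-yl in place of 4-(1H-pyrazol-1-yl)phenyl on a saturated chain carbon bound to a nitrogen on an aromatic ring. For the measured compounds named here, the only measured step, a 2.0-fold lower number from compound 1 to compound 2 (0.29 log units; within the scatter), put 1H-pyrazol-1-yl in place of 2-methoxyphenyl and stayed within the scatter, so no change beyond the scatter is expected. The expected step is a 1.2-fold higher number from compound 2 to compound 3 (0.07 log units; within the scatter). For compound 3 the estimate is 200 nM, with an expected range of 70 nM to 570 nM.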

Compound 3, half-maximal inhibitory concentration: 40 nM
Compound 3: middle estimate off by 5.0-fold (0.70 log units), on the high side, outside the stated range (below it).
By their numbers in this assay, from the lowest: compound 3; then compounds 2 and 1 (each within the scatter of the next).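

In this assay the step at this position, a 4.3-fold lower number from compound 2 to compound 3 (0.63 log units; beyond the scatter), is the first one shown that lies beyond the scatter, so the group on this saturated chain carbon can shift the number. The leaving and entering groups have the same counts of heavy atoms, hydrogen-bond donors and hydrogen-bond acceptors, so those counts do not separate them, while their rings and hetero atoms differ. Nothing measured here accounts for the step. Both rings of the group change at once, so the compounds shown leave open which ring carries the step. As far as these compounds go, it also remains open whether a furan in place of the thiophene would keep it.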